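The source may hold more compounds than are shown below. What is called first, only, known or untested is meant among the compounds shown, and "the series" means these compounds.

Compound 1 `CNCCNCc1cccc(-c2nc(NC3CCOCC3)c(C)c(-c3ccnc4[nH]ccc34)n2)c1` is the only one of the three measured compounds to give a number in a functional assay on BT-549 cells (Homo sapiens) for inhibition, read by sulforhodamine B assay, with a stated time of 6 days; a lower number here means a stronger inhibitor, a higher number a weaker inhibitor: compound 1 gives 25200 nM. Compound 2 `CNCCNCc1cccc(-c2nc(NC3CCOCC3)c(C)c(-c3cn(C)nc3C)n2)c1` gives only the limit of the assay, > 50000 nM. Compound 3 `CNCCNCc1cccc(-c2nc(NC3CCOCC3)c(C)c(-c3cccnc3)n2)c1` likewise gives only the limit, > 50000 nM. The steps of an at least 1.9-fold higher number from compound 1 to compound 2 (0.29 log units; that floor lies within the scatter) and an at least 1.9-fold higher number from compound 1 to compound 3 (0.29 log units; that floor lies within the scatter) both point toward weaker inhibition, though each floor lies within the scatter. Compound 4 `CNCCNCc1cccc(-c2nc(NC3CCOCC3)c(C)c(-c3ccnn3C)n2)c1` alters compound 1 at the same place: a group of 6 heavy atoms (4 carbon, 2 nitrogen; one five-membered aromatic ring with 2 hetero atoms) in place of a group of 9 heavy atoms (7 carbon, 2 nitrogen; one five-membered aromatic ring with 1 hetero atom, one six-membered aromatic ring with 1 hetero atom), on an aromatic carbon. Both measured swaps at this position to a smaller ring ended at the limit of > 50000 nM in this assay, at which 2 of the 3 values shown sit, so compound 4 is expected to sit near that limit as well, with a step of a 2.4-fold higher number from compound 1 to compound 4 (0.38 log units; beyond the scatter). The estimate for compound 4 is 60000 nM, with a range from 25000 nM to 150000 nM.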

Compound 4, half-maximal inhibitory concentration: > 50000 nM
Compound 4 was reported as a limit (the forecaster's own chance of this, stated with the estimate: 65%); the middle value does not contradict the limit.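

The swap to 1-methyl-1H-pyrazol-5-yl gives an at least 1.9-fold higher number from compound 1 to compound 4 (0.29 log units; that floor lies within the scatter), so a third smaller ring at this place on the shared core also yields no number. Compound 4 gives only a limit, not a number: the limit of > 50000 nM in this assay, at which 3 of the 4 values shown sit. The steps among compound 2, compound 3 and compound 4 cannot be read, so these rings cannot be ranked.

Going by these compounds, it remains open whether the two-ring group of compound 1 matters for its size or for its hydrogen-bond donor, which 1-methyl-1H-pyrazol-5-yl lacks. An aminopyridinyl group here could help separate the two.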